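A Methyl for a Fluoro on the Aryl Ketone

This account rests on a few compounds, and the source may have more. Where it says the series, first, only, none or still open, it means among the compounds named here.

Three esters built on a shared core were tested in a functional assay on CCRF-CEM cells (Homo sapiens) for antiproliferative activity, read by MTT assay, with a stated time of 72 h, tested at 100 uM; on this read-out higher numbers stand for a weaker effect at the one concentration tested and lower numbers for a stronger effect. Compound 1, `CC(Cn1cnc2c1c(=O)n(C)c(=O)n2C)OC(=O)CC(=O)c1ccc(F)cc1`, gives 43.8%, the highest number of the three. Compound 2, `COC(C(=O)OC(C)Cn1cnc2c1c(=O)n(C)c(=O)n2C)c1ccc2ccccc2c1`, gives 27.6%, a number lower than that of compound 1 by more than the usual scatter. Compound 3, `CC(Cn1cnc2c1c(=O)n(C)c(=O)n2C)OC(=O)Sc1ccccc1`, gives 14.5%, the lowest of the three and again separated from compound 1 by more than the scatter. No two of these compounds differ in only one place, so none of these gaps can be tied to a single structural change.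

Compound 4, `Cc1ccc(C(=O)CC(=O)OC(C)Cn2cnc3c2c(=O)n(C)c(=O)n3C)cc1`, has not yet been measured. It is related to compound 1 by one change: methyl in place of fluoro on an aromatic carbon. The rest of the molecule, the ester linker, the ketone and the core, is unchanged.

Within the data shown here, nothing among the measured compounds shows what this exchange does. Given a single small substituent swapped for another of the same size on the ring, the step from compound 1 to compound 4 is expected to be small, a number 1.2 percentage points higher from compound 1 to compound 4 (within the scatter), and not beyond the scatter in either direction. Compound 4 is therefore estimated to give 45% in this assay, within a range of 25% to 65%.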

Compound 4, a percentage reported as activity, at one concentration (the size of the read-out at that concentration, not a potency): 67.3%
Beside the measured number, compound 4's estimate is 22.3 percentage points below it; measured number above the stated range.
By their numbers in this assay, from the lowest: compound 3; then compound 2; then compound 1; then compound 4.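

In this assay the exchange of fluoro for methyl gives a number 23.5 percentage points higher from compound 1 to compound 4 (beyond the scatter) and so a weaker effect at the one concentration tested. Among these compounds, this is the first comparison in the set that can be tied to a single structural change, and it shows that this aromatic carbon, para to a large group, is not indifferent to what it carries, even though one heavy atom simply replaces another and no ring, hydrogen-bond donor, hydrogen-bond acceptor or net charge enters or leaves. Nothing available accounts for the size of this step, which therefore stands as an observation without an explanation.

The compounds shown leave open how other groups at this carbon would compare, such as a chloro, a methoxy, an amine or a plain hydrogen, and so whether fluoro and methyl mark the ends of a wider spread or two points within it. They also leave open whether the same exchange would produce a step of similar size on the aromatic ring of compound 3, since a single pair of compounds speaks only for its own scaffold.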